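The compounds below may be only part of what the source reports. "The series", "measured", "known", "first", "only" and "open" are said of these compounds alone.

Measured compounds:
compound 1 `c1ccc(-c2cn3ccnc3c(-c3ccc4ncn(C5CCCCC5)c4c3)n2)cc1` — 51.6%
compound 2 `c1ccc2c(-c3cn4ccnc4c(-c4ccc5ncn(C6CCCCC6)c5c4)n3)cccc2c1` — 4.46%

In a functional assay on HCT-15 cells (Homo sapiens) for inhibition, read by sulforhodamine B assay, with a stated time of 48 h, tested at 10 uM (on this read-out lower numbers stand for less inhibition and higher numbers for more inhibition at the one concentration tested (going by the name of the read-out)), compound 1 gives 51.6%, and compound 2 gives 4.46%. Compound 2 stands lowest of the two numbers, and its nearest neighbour is compound 1, from which it differs by a number 47.1 percentage points lower from compound 1 to compound 2 (beyond the scatter), a large step that arose when naphthalen-1-yl took the place of phenyl on an aromatic carbon. Compound 3 `Clc1ccc(-c2cn3ccnc3c(-c3ccc4ncn(C5CCCCC5)c4c3)n2)cc1` has not yet been measured in this assay. It differs from compound 2 by 4-chlorophenyl in place of naphthalen-1-yl on an aromatic carbon. Among the measured compounds shown here, the one measured step that bears on this change is a number 47.1 percentage points lower from compound 1 to compound 2 (beyond the scatter), since it too swaps naphthalen-1-yl and a single six-membered aromatic ring at the same place, only in the opposite direction. Compound 3 carries a 4-chlorophenyl group, which is closer to the phenyl of compound 1 than to the naphthalen-1-yl of compound 2, so a step upward is expected, estimated at a number 40.5 percentage points higher from compound 2 to compound 3 (beyond the scatter). How the chlorine itself affects the read-out is not shown by any measured pair, so the expectation is broad. For compound 3 the estimate in this assay is 45%, with a range from 20% to 70%.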

Compound 3, a percentage reported as inhibition, at one concentration (the size of the read-out at that concentration, not a potency): 15.5%
Compound 3: the middle estimate sits 29.5 percentage points above what was measured, and the stated range ends above it.
By their numbers in this assay, from the lowest: compound 2; then compound 3; then compound 1.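

In this assay, chloro in place of hydrogen on the phenyl ring of compound 1 brings a number 36.1 percentage points lower from compound 1 to compound 3 (beyond the scatter) and takes away most of the inhibition, so a single six-membered aromatic ring at this place does not by itself keep the read-out of compound 1. Among the compounds shown here, the change from naphthalen-1-yl to 4-chlorophenyl brings a number 11 percentage points higher from compound 2 to compound 3 (beyond the scatter) and is only modest, which leaves compound 2 and compound 3 both far under compound 1, the highest of the three, with unsubstituted phenyl the only group here that gives strong inhibition. The compounds shown offer no independent measurement that could explain why either replacement of phenyl lowers the read-out.

From the compounds shown here alone, what stays open is whether this loss belongs to chloro in particular or would follow any group put in its place on the phenyl ring, and a methoxy group, an amine or a carboxylic acid there would be the direct comparison. With one concentration per compound, these numbers also leave open how the three compounds would rank across a range of concentrations.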